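Swapping chloro for trifluoromethyl on one aromatic carbon

This account rests on a few compounds, and the source may have more. Where it says the series, first, only, none or still open, it means among the compounds named here.

Values so far in an ADME assay for permeability, using PAMPA; on this read-out higher numbers stand for higher permeability and lower numbers for lower permeability
- compound 1 (`O=C(Nc1ccccc1Cl)c1cc(Cl)ccc1O`) gives 118 10^-6 cm/s
- compound 2 (`O=C(Nc1ccc(C(F)(F)F)cc1Cl)c1cc(Cl)ccc1O`) gives "not determined" (no result reported)

Going by the values given here, compound 1 holds the only number so far, so it cannot yet be ranked against anything. Compound 3 (`O=C(Nc1ccccc1C(F)(F)F)c1cc(Cl)ccc1O`) differs from compound 1 in one place (trifluoromethyl in place of chloro on an aromatic carbon), with trifluoromethyl in place of chloro on an aromatic carbon. Among the compounds with values here, no measured pair shows what such a swap does, so the expectation in this assay is a step no larger than the usual scatter, in no firm direction. In numbers, the estimate expects a 1.1-fold lower number from compound 1 to compound 3 (0.03 log units; within the scatter) here. Compound 3 is expected at 110 10^-6 cm/s within a range of 45 10^-6 cm/s to 250 10^-6 cm/s in this estimate.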

Compound 3, apparent permeability: 26 10^-6 cm/s
Compound 3: middle estimate off by 4.2-fold (0.63 log units), on the high side; the whole stated range lies above it.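

In this assay this position turns out not to be indifferent to the group it carries. Trifluoromethyl in place of chloro, on an aromatic carbon ortho to a large group, gives a 4.5-fold lower number from compound 1 to compound 3 (0.66 log units; beyond the scatter) and so moves the number beyond the usual scatter. No measurement at hand bears on why this step occurs.

One swap leaves open how other groups would behave here, such as a methyl, an amine or a carboxylic acid. It also leaves open whether the same swap elsewhere on the core of compound 1 would give a step of similar size.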